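A few compounds are considered here, and "the series" means these few. Any claim that something is new, unique, unknown or untested is made for them only; others in the source may bear on it.

Working notes on the series. The shared core is that of compound 1 `CCC(C)(C)Cc1c[nH]c(CCc2ccc(-c3ccncc3)cc2)n1`, which in a functional assay on HEK293 cells for agonist activity at Bombesin receptor subtype-3 (Mus musculus), read by luminescence and calcium flux, with a stated time of 10 min (on this read-out lower numbers stand for an effect already at smaller amounts and higher numbers for an effect only at larger amounts of compound), gives 15 nM. Compound 2 `CCC(C)(C)Cc1c[nH]c(CCc2ccc(-c3cnccn3)cc2)n1` gives 11 nM, and compound 3 `CCC(C)(C)Cc1c[nH]c(CCc2ccc(-c3cccc(N)n3)cc2)n1` gives 3.9 nM. On these numbers compound 2 stands second highest of the three; its nearest neighbour is compound 1, with a 1.4-fold lower number from compound 1 to compound 2 (0.13 log units; within the scatter), and its furthest is compound 3, with a 2.8-fold lower number from compound 2 to compound 3 (0.45 log units; beyond the scatter). For comparison, a 3.8-fold lower number from compound 1 to compound 3 (0.59 log units; beyond the scatter).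

Compound 4 `CCC(C)(C)Cc1c[nH]c(CCc2ccc(-c3cccnc3C(=O)O)cc2)n1` has not yet been measured. 2-carboxypyridin-3-yl in place of pyrazin-2-yl on an aromatic carbon The measured steps at this aromatic carbon are the two above: exchanging one six-membered ring bearing two hetero atoms for another stays within the scatter, while a 6-aminopyridin-2-yl in place of either ring gives a modest gain. Among the compounds with values here, no measured step introduces a carboxylic acid, so direct precedent is lacking and the change is larger than any step recorded here. A shift beyond the scatter in either direction cannot be excluded; the working expectation is for a somewhat higher number, with a 2.3-fold higher number from compound 2 to compound 4 (0.36 log units; beyond the scatter). Compound 4 is therefore expected to give about 25 nM in this assay, within 6 nM to 120 nM.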

Compound 4, half-maximal effective concentration: 14 nM
Compound 4: middle estimate off by 1.8-fold (0.25 log units), on the high side, within the range that was stated.
By their numbers in this assay, from the lowest: compound 3; then compounds 2, 4 and 1 (each within the scatter of the next).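

The earlier compounds shown here held only ring nitrogens and an amine at this aromatic carbon, and the 2-carboxypyridin-3-yl group now shows that a larger substituent carrying a carboxylic acid can sit on it with no change beyond the scatter in this assay, with a 1.3-fold higher number from compound 2 to compound 4 (0.10 log units; within the scatter) and a 1.1-fold lower number from compound 1 to compound 4 (0.03 log units; within the scatter) as the two steps that show this. The 6-aminopyridin-2-yl group keeps its modest advantage against this new group as well, with a 3.6-fold higher number from compound 3 to compound 4 (0.56 log units; beyond the scatter), so every step beyond the scatter in the series still involves compound 3. No measurement at hand accounts for these numbers.

Still open, going by these compounds, is whether the carboxylic acid itself plays any part in the result for compound 4, which its methyl ester or primary amide at the same aromatic carbon would test. Also open, on these data alone, is whether the amine of compound 3 accounts for its lower number, which a plain pyridin-2-yl group, or a methylamino group in place of the amine, would begin to answer.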